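A few compounds are considered here, and "the series" means these few. Any claim that something is new, unique, unknown or untested is made for them only; others in the source may bear on it.

Measured compounds:
- compound 1, `Cc1nc(C#Cc2cc(Cl)cc(C#N)c2)cs1`: in an assay on HEK293 cells for displacement of a labelled ligand from metabotropic glutamate receptor 5 (Rattus norvegicus), read by scintillation counting (a higher number here means a weaker inhibitor, a lower number a stronger inhibitor), compound 1 gives 0.127 nM
- compound 2, `Cc1nc(C#Cc2cc(Br)cc(C#N)c2)cs1`: in this assay compound 2 gives 0.106 nM

Compound 2 carries the lower of the two numbers, but its gap to compound 1 is within the scatter: the step of a 1.2-fold lower number from compound 1 to compound 2 (0.08 log units; within the scatter) does not separate the two compounds, so neither can be called the stronger inhibitor on these data.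

Compound 3, `Cc1nc(C#Cc2cc(I)cc(C#N)c2)cs1`, continues this halogen exchange: iodo in place of bromo on an aromatic carbon. Among the measured compounds shown here, the only measured step that bears on it is the earlier exchange at the same carbon, a 1.2-fold lower number from compound 1 to compound 2 (0.08 log units; within the scatter), which stayed within the scatter. A second exchange within the same halogen family at the same place is therefore expected to leave the number where it is, with no step beyond the scatter; the step expected is a 1.1-fold lower number from compound 2 to compound 3 (0.03 log units; within the scatter). On that basis compound 3 is estimated at 0.1 nM in this assay, with a range from 0.05 nM to 0.25 nM. Only compound 1 and compound 2 support this expectation; no other halogen change in this series has been measured.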

Compound 3, inhibition constant: 2.14 nM
Beside the measured number, compound 3's estimate is 21-fold (1.33 log units) below it; measured number outside the range, above it.
By their numbers in this assay, from the lowest: compounds 2 and 1 (each within the scatter of the next); then compound 3.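

In this assay this carbon, meta to a cyano group, does not treat all halogens alike: iodo in place of bromo gives a 20-fold higher number from compound 2 to compound 3 (1.31 log units; beyond the scatter) and iodo in place of chloro gives a 17-fold higher number from compound 1 to compound 3 (1.23 log units; beyond the scatter) in a series where chloro and bromo could not be told apart. The change is a single heavy atom for a single heavy atom, with no ring, hydrogen-bond donor, hydrogen-bond acceptor or net charge entering or leaving, so even an exchange this small at this place can move the number well beyond the scatter. The position is therefore not indifferent to its halogen, and the agreement of compound 1 with compound 2 does not extend to iodo, leaving compound 3 the weakest inhibitor of the three.

Still open, from the compounds shown here alone, is whether the rise belongs to iodo alone or also comes with other groups on this carbon, such as fluoro, methyl, methoxy or an amine, and whether it persists when the nitrile is replaced. The data shown include no measurement that would explain the rise.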